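Phenyl in place of nonyl: the expected dose for compound 4

The compounds below may be only part of what the source reports. "The series", "measured", "known", "first", "only" and "open" are said of these compounds alone.

Compound 1 `CCCCCCOc1ccc(-n2cnnc2)cc1` carries hydrogen on the aromatic carbon of the shared core, and in a functional assay on the whole organism (strain C57B/6) with Mus musculus as the target, in the maximal electroshock model (on this read-out higher numbers stand for an effect only at larger amounts of compound and lower numbers for an effect already at smaller amounts), compound 1 gives 9.8 mg/kg. Compound 2 `CCCCCCOc1ccc(-n2cnnc2CCCCC)cc1` bears pentyl there, and in this assay compound 2 gives 32.8 mg/kg; the step is a 3.3-fold higher number from compound 1 to compound 2 (0.52 log units; beyond the scatter). Compound 3 `CCCCCCCCCc1nncn1-c1ccc(OCCCCCC)cc1` bears nonyl. In this assay compound 3 reaches only a limit of > 40 mg/kg, so its number is not known (the limit of > 40 mg/kg in this assay, at which 1 of the 3 values shown sits). The step of an at least 4.0-fold higher number from compound 1 to compound 3 (0.61 log units; beyond the scatter) and the step of an at least 1.2-fold higher number from compound 2 to compound 3 (0.08 log units; that floor lies within the scatter) both point toward larger doses as the group on that carbon grows. Compound 4 `CCCCCCOc1ccc(-n2cnnc2-c2ccccc2)cc1` differs from compound 3 by phenyl in place of nonyl on an aromatic carbon. Phenyl is a smaller group than nonyl, so the estimate places compound 4 at 25 mg/kg, with a range from 10 mg/kg to 60 mg/kg. That corresponds to an expected step of an at least 1.6-fold lower number from compound 3 to compound 4 (0.20 log units; that floor lies within the scatter).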

Compound 4, dose for half-maximal effect: 19 mg/kg
Estimate against measurement, compound 4: 1.3-fold (0.12 log units) above, within the range that was stated.
By their numbers in this assay, from the lowest: compounds 1, 4 and 2 (each within the scatter of the next, the first and the last beyond it). At a limit, above all of these: compound 3.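

Among the compounds shown here, on this carbon between two ring nitrogen atoms, phenyl brings in a ring for the first time, and in this assay it stays within the scatter of both hydrogen (a 1.9-fold higher number from compound 1 to compound 4 (0.29 log units; within the scatter)) and pentyl (a 1.7-fold lower number from compound 2 to compound 4 (0.24 log units; within the scatter)). Against nonyl, the change reads beyond the scatter (an at least 2.1-fold lower number from compound 3 to compound 4 (0.32 log units; beyond the scatter)). That step is only a floor, as compound 3 stands at a limit: the limit of > 40 mg/kg in this assay, at which 1 of the 4 values shown sits.

From the compounds shown here alone, how compound 3 truly compares with compound 4 stays open. So does whether a pyridine ring, an amine or a carboxylic acid on this carbon would stay in this range.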